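The compounds below may be only part of what the source reports. "The series", "measured", "known", "first", "only" and "open" are said of these compounds alone.

Measured compounds and their values:

Compound 1, `C#Cc1cn([C@@H]2O[C@H](CO)[C@@H](O)[C@H]2O)c2ncnc(NC)c12`: in a functional assay on HCT-116 cells (Homo sapiens), read by MTT assay, with a stated time of 72 h (a lower number here means a stronger inhibitor, a higher number a weaker inhibitor), compound 1 reaches only the assay limit of > 20000 nM.

Compound 2, `CNc1ncnc2c1c(-c1cccs1)cn2[C@@H]1O[C@H](CO)[C@@H](O)[C@H]1O`: in this assay compound 2 likewise stops at the limit of > 20000 nM.

Compound 3, `CNc1ncnc2c1c(-c1ccsc1)cn2[C@@H]1O[C@H](CO)[C@@H](O)[C@H]1O`: in this assay compound 3 also stops at the limit of > 20000 nM.

Compound 1 therefore stands at the limit of this assay, as do the other two measured compounds, which is all that the limit of > 20000 nM in this assay, at which 3 of the 3 values shown sit, records. The three measured steps are a step that the two limits leave unreadable from compound 1 to compound 2, a step that the two limits leave unreadable from compound 1 to compound 3 and a step that the two limits leave unreadable from compound 2 to compound 3; each alters the ethynyl or thiophene position and none can be read in size. The unmeasured compound 4, `C#Cc1cn([C@@H]2O[C@H](CO)[C@@H](O)[C@H]2O)c2ncnc(SC)c12`, differs from compound 1 at a different place: methylsulfanyl in place of methylamino on an aromatic carbon. Among the measured compounds shown here, no measured step concerns this position, so the measured data give no readable guide to its direction or size. Given that compound 1 sits at the limit of > 20000 nM, compound 4 is expected to remain near or beyond that limit, with an estimate of 25000 nM in this assay, spanning 5000 nM to 100000 nM. The step that the limit leaves unreadable from compound 1 to compound 4 is thus expected to be none beyond the scatter.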

Compound 4, half-maximal inhibitory concentration: 90 nM
Beside the measured number, compound 4's estimate is 280-fold (2.44 log units) above it; measured number below the stated range.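

In this assay, among the compounds shown here, methylsulfanyl in place of methylamino gives an at least 220-fold lower number from compound 1 to compound 4 (2.34 log units; beyond the scatter), so this position, which no earlier step touched, can carry the whole difference between an assay limit and a measured value. The earlier steps shown here, all at the ethynyl or thiophene position and all with methylamino kept, cannot be read, and the set's other compounds remain at the limit: the limit of > 20000 nM in this assay, at which 3 of the 4 values shown sit. The change takes away the hydrogen-bond donor of methylamino and brings in sulfur for nitrogen, and the data do not separate these two differences.

As far as these compounds go, it remains open whether methylsulfanyl would give a measurable value with the thiophen-2-yl or thiophen-3-yl group of compound 2 and compound 3 in place of ethynyl. From the compounds shown here alone, it is also open whether methoxy or the longer ethylsulfanyl at this place would give a similarly low number.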